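Compound 2 to compound 4: bromo to methoxy

This account rests on a few compounds, and the source may have more. Where it says the series, first, only, none or still open, it means among the compounds named here.

Compound 1 `C/C(=N\O)c1ccc(OCc2ccc(C(=O)NO)cc2)cc1` gives 7770 nM
Compound 2 `Nc1ccccc1NC(=O)c1ccc(COc2ccc(Br)cc2)cc1` gives > 32000 nM
Compound 3 `O=C(/C=C/c1ccc(CN2CCc3ccccc32)cc1)NO` gives 14900 nM

All three values come from a functional assay on HepG2 cells (Homo sapiens) for antiproliferative activity, read by CCK-8 assay, with a stated time of 72 h; a lower number here means a stronger inhibitor, a higher number a weaker inhibitor. Compound 1 (7770 nM) and compound 3 (14900 nM) lie within the usual scatter of each other. Compound 2 has no numeric value, only a limit of the assay (> 32000 nM). That reading is the limit of > 32000 nM in this assay, at which 1 of the 3 values shown sits. Within the data shown here, no two measured compounds differ in one place, so the series offers no measured step to serve as a guide.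

The unmeasured compound 4 `COc1ccc(OCc2ccc(C(=O)Nc3ccccc3N)cc2)cc1` keeps the core of compound 2 and changes one substituent: methoxy in place of bromo on an aromatic carbon. In words, this is methoxy in place of bromo on an aromatic carbon, para to a large group, or 4-bromophenyl to 4-methoxyphenyl.

Among the measured compounds shown here, with no measured precedent for this change, no step beyond the scatter is expected in this assay, and neither direction is favoured. The expected step of a number no higher from compound 2 to compound 4 (the limit leaves the size open) is therefore small. Compound 4 may well also reach the limit of the assay and return no number. The estimated value for compound 4 is 32000 nM (expected range 14000 nM to 70000 nM).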

Compound 4, half-maximal inhibitory concentration: 4200 nM
Compound 4: the middle estimate sits 7.6-fold (0.88 log units) above what was measured; measured number below the stated range.
By their numbers in this assay, from the lowest: compounds 4, 1 and 3 (each within the scatter of the next, the first and the last beyond it). At a limit, above all of these: compound 2.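

In this assay, the change from 4-bromophenyl to 4-methoxyphenyl, on an aromatic carbon para to a large group, gives an at least 7.6-fold lower number from compound 2 to compound 4 (0.88 log units; beyond the scatter), the only measured step in the compounds shown, so this position does respond to the substituent it carries. The size of that step is only a bound, as compound 2 holds a limit of the assay and not a number: the limit of > 32000 nM in this assay, at which 1 of the 4 values shown sits. The core of compound 2 is therefore able to return a number once methoxy replaces bromo, with compound 4 giving 4200 nM in this assay.

This single pair leaves open how other groups at the same position, such as chloro, hydroxyl or an amine, would read in this assay, and so whether the oxygen or the added carbon of the methoxy group matters more. It also leaves open whether a step of this kind would carry over to a different core, such as that of compound 1.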